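Adding Bromo to the Fused Ring of Compound 3

The compounds below may be only part of what the source reports. "The series", "measured", "known", "first", "only" and "open" are said of these compounds alone.

Compound 3 `COc1ccc(CN(C(=O)CSc2nc3ccccc3s2)c2cc(OC)c(OC)c(OC)c2)cc1O` gives the lowest of the three numbers in a functional assay on MGC-803 cells (Homo sapiens) for antiproliferative activity, read by MTT assay, with a stated time of 48 h; a higher number here means a weaker inhibitor, a lower number a stronger inhibitor: in this assay compound 3 gives 35 nM. Among the measured compounds shown here, its nearest neighbour is compound 1 `COc1ccc2nc(SCC(=O)N(Cc3ccc(OC)c(O)c3)c3cc(OC)c(OC)c(OC)c3)sc2c1`, which in this assay gives 71 nM; the step of a 2.0-fold lower number from compound 1 to compound 3 (0.31 log units; beyond the scatter) is the only measured change on the fused two-ring part of the shared core, and it was modest. Compound 2 `COc1ccc(CN(C(=O)CSc2nc3ccccc3s2)c2cc(OC)c(OC)c(OC)c2)cc1C` stands furthest away, giving 6360 nM in this assay, and the step of a 180-fold lower number from compound 2 to compound 3 (2.26 log units; beyond the scatter) is large, though it concerns a different part of the molecule.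

Compound 4 `COc1ccc(CN(C(=O)CSc2nc3cc(Br)ccc3s2)c2cc(OC)c(OC)c(OC)c2)cc1O` differs from compound 3 by a single change: bromo in place of hydrogen on an aromatic carbon. This places a substituent once more on the fused ring of the shared core. For the measured compounds named here, the step of a 2.0-fold lower number from compound 1 to compound 3 (0.31 log units; beyond the scatter) suggests that a substituent on that ring shifts the number only modestly, so a small step at most is expected, if anything toward a higher number, since the one measured change there helped when the substituent was removed. Compound 4 is therefore estimated at 55 nM, with a range from 20 nM to 160 nM, corresponding to an expected step of a 1.6-fold higher number from compound 3 to compound 4 (0.20 log units; within the scatter).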

Compound 4, half-maximal inhibitory concentration: 372 nM
Compound 4: middle estimate off by 6.8-fold (0.83 log units), on the low side; measured number above the stated range.
By their numbers in this assay, from the lowest: compound 3; then compound 1; then compound 4; then compound 2.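

Among the compounds shown here, on the fused ring of the shared core, a substituent is not always a minor matter: bromo in place of hydrogen on this aromatic carbon, meta to a fused ring and para to a fused ring, gives an 11-fold higher number from compound 3 to compound 4 (1.03 log units; beyond the scatter) in this assay, a large step where the one earlier change on that ring, a 2.0-fold lower number from compound 1 to compound 3 (0.31 log units; beyond the scatter), was modest. The two substituted compounds on that ring, compound 1 and compound 4, both give higher numbers than the unsubstituted compound 3, and none of the compounds shown goes against this, yet the size of the penalty differs with the group and its place on the ring. The comparison between the two substituted compounds, a 5.2-fold higher number from compound 1 to compound 4 (0.72 log units; beyond the scatter), shows that the bromo compound also stands well behind the methoxy compound, a change of group that also involves a different carbon of that ring.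

Nothing given here explains why bromo costs so much at this position. The compounds shown leave open whether chloro, fluoro, an amine or a carboxylic acid on this same carbon would follow bromo or stay close to compound 3.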